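The source may report more compounds than this note shows. Statements on the series, on what has been measured and on what is new or still open speak of the compounds shown alone.

Measured so far in an ADME assay on HepG2 cells (Homo sapiens) for cytotoxicity, read by MTT assay, with a stated time of 48 h; a higher number here means that more compound is tolerated, a lower number that less compound is tolerated:
Compound 1 `CC(=O)OC[C@H]1O[C@H](OC[C@@H](Cn2cc(CN(c3nc(-c4cccc([N+](=O)[O-])c4)no3)C3CCCCC3)nn2)OC(C)=O)C=C[C@@H]1OC(C)=O` gives > 200 ug/mL, which is a limit of the assay and not a number.
Compound 2 `C#Cc1ccc(-c2noc(NC3CCCCC3)n2)cc1` gives 54.2 ug/mL.
Compound 3 `CC(=O)OC[C@H]1O[C@H](OC[C@@H](Cn2cc(CN(c3nc(-c4ccc(Br)cc4)no3)C3CCCCC3)nn2)OC(C)=O)C=C[C@@H]1OC(C)=O` gives 47.6 ug/mL.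

Compound 2 and compound 3 sit within the scatter of each other, so no order between them is claimed. Compound 1 stands apart only as a limit, (the limit of > 200 ug/mL in this assay, at which 1 of the 3 values shown sits). Among the compounds with values here, the single measured step, an at least 4.2-fold lower number from compound 1 to compound 3 (0.62 log units; beyond the scatter), exchanges one aryl substituent for another on the core of compound 1 and says nothing about the phenyl substituent of compound 2.

Compound 4 `C#CCOc1ccc(-c2noc(NC3CCCCC3)n2)cc1` differs from compound 2 by propargyloxy in place of ethynyl on an aromatic carbon. Within the data shown here, no measured step covers a change of this kind at this place, and the step from compound 1 to compound 3 does not transfer to it. The expectation is therefore no step beyond the scatter: a 1.0-fold higher number from compound 2 to compound 4 (0.01 log units; within the scatter) is expected to be small, with the range widened for the lack of a comparable step. Compound 4 is estimated at 55 ug/mL, between 25 ug/mL and 120 ug/mL, in this assay.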

Compound 4, half-maximal cytotoxic concentration: 119 ug/mL
For compound 4 the middle estimate is 2.2-fold (0.34 log units) below the measured one, within the range that was stated.
By their numbers in this assay, from the lowest: compounds 3 and 2 (each within the scatter of the next); then compound 4. At a limit, above all of these: compound 1.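

In this assay there is a 2.2-fold higher number from compound 2 to compound 4 (0.34 log units; beyond the scatter) with propargyloxy in place of ethynyl on an aromatic carbon para to a large group, so the number at this place does respond to the substituent. Both groups hold a triple bond outside aromatic rings, so that feature alone does not separate the two compounds; what differs is the oxygen, a hydrogen-bond acceptor, and the longer chain of the entering group. No measurement shown here accounts for the step.

Whether the oxygen or the chain length goes with the higher number stays open, as the compounds shown do not include a methoxy group, a propyl chain or an amine at this place. Going by these compounds, whether the same exchange carries over to the core of compound 1 is also open.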